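A few compounds are considered here, and "the series" means these few. Any claim that something is new, unique, unknown or untested is made for them only; others in the source may bear on it.

Compound 1 `CCCSc1nc(N[C@@H]2C[C@H]2c2ccc(F)c(F)c2)c2nnn([C@@H]3C[C@H](OCCOC(=O)OCC)[C@@H](O)[C@H]3O)c2n1` gives 47.7% in a functional assay on the whole organism (strain Sprague-Dawley) for inhibition, with Rattus norvegicus as the target, with a stated time of 0.5 h, at a dose of 5 mg/kg by the oral route; a lower number here means less inhibition, a higher number more inhibition at the dose given (going by the name of the read-out).
Compound 2 `CCCSc1nc(N[C@@H]2C[C@H]2c2ccc(F)c(F)c2)c2nnn([C@@H]3C[C@H](OC(=O)CC)[C@@H](O)[C@H]3O)c2n1` gives 44.5% in this assay.

Among these two compounds, compound 2 has the lowest number in this assay, and its nearest neighbour is compound 1, whose number sits higher by an amount that is within the usual scatter, so the two cannot be told apart on this read-out.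

Compound 3 `CCCSc1nc(N[C@@H]2C[C@H]2c2ccc(F)c(F)c2)c2nnn([C@@H]3C[C@H](OC(=O)CCC)[C@@H](O)[C@H]3O)c2n1` has not yet been measured. It differs from compound 2 in one place: methyl in place of hydrogen on a saturated chain carbon, two bonds along the chain from a carbonyl carbon.

Among the compounds with values here, only one measured step bears on this change. The step of a number 3.2 percentage points lower from compound 1 to compound 2 (within the scatter) replaced the whole group on the same oxygen on a saturated carbon with a smaller one, and the read-out barely moved. Compound 3 carries a still smaller alteration, a methyl in place of hydrogen two bonds along the chain from the carbonyl carbon, on that same group. Compound 3 is therefore expected to show no step beyond the scatter, with a number 0.5 percentage points higher from compound 2 to compound 3 (within the scatter) as the expected change. The estimated value for compound 3 is 45%, with a range from 30% to 60%.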

Compound 3, a percentage reported as inhibition, in the whole organism at one dose (the size of the read-out at that dose, not a potency): 28.5%
Estimate against measurement, compound 3: 16.5 percentage points above, and the stated range ends above it.
By their numbers in this assay, from the lowest: compound 3; then compounds 2 and 1 (each within the scatter of the next).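

In this assay, a methyl in place of hydrogen on a saturated chain carbon, two bonds along the chain from a carbonyl carbon, gives a number 16 percentage points lower from compound 2 to compound 3 (beyond the scatter) and so goes beyond the scatter, which shows that this chain position responds to the addition of a single carbon, even though the earlier exchange of the whole group on the same oxygen left the two compounds indistinguishable. The comparison with the larger group gives a number 19.2 percentage points lower from compound 1 to compound 3 (beyond the scatter) and also goes beyond the scatter, so among these three compounds the read-out does not follow group size: the groups of 8 and 4 heavy atoms cannot be told apart, while the group of 5 heavy atoms gives the lowest number. Nothing available explains why the added methyl has this effect.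

The compounds shown leave open whether a longer chain, such as a pentanoyl group, would lower the number further or whether the drop is confined to this one extension. They also leave open how a branched isobutyryl group or an amine on the same chain would read at this single dose and time.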